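The source may report more compounds than this note shows. Statements on the series, on what has been measured and on what is new or still open speak of the compounds shown alone.

Compound 2 `CC(C)(C)c1ccc(NC(=O)NCCCCl)cc1` gives 28000 nM in a functional assay on HT-29 cells (Homo sapiens) for antiproliferative activity, with a stated time of 48 h (on this read-out lower numbers stand for stronger inhibition and higher numbers for weaker inhibition), the lowest of the two numbers in hand. Among the compounds with values here, compound 1 `O=C(NCCCCl)Nc1ccc(I)cc1` gives 90000 nM in this assay, and the single measured step, a 3.2-fold lower number from compound 1 to compound 2 (0.51 log units; beyond the scatter), was modest. Compound 3 `CC(C)(C)c1ccc(NC(=O)CCCl)cc1` differs from compound 2 by 2-chloroethyl in place of (3-chloropropyl)amino on a carbonyl carbon on a carbonyl carbon whose other neighbour is an amide-type nitrogen. Within the data shown here, no measured step touches this part of the molecule, so no direction can be argued from the data, and a change within or near the scatter is the default expectation. Compound 3 is therefore estimated at 30000 nM, range 8000 nM to 100000 nM, meaning an expected step of a 1.1-fold higher number from compound 2 to compound 3 (0.03 log units; within the scatter).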

Compound 3, half-maximal inhibitory concentration: 88000 nM
Beside the measured number, compound 3's estimate is 2.9-fold (0.47 log units) below it; low and high end bracket the measured number.
By their numbers in this assay, from the lowest: compound 2; then compounds 3 and 1 (each within the scatter of the next).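

Putting 2-chloroethyl in place of (3-chloropropyl)amino on the carbonyl carbon gives a 3.1-fold higher number from compound 2 to compound 3 (0.50 log units; beyond the scatter), so this side of the carbonyl also affects the read-out, not only the aromatic substituent. The change removes the nitrogen with its hydrogen-bond donor and also goes from 5 heavy atoms to 3, and these two differences cannot be separated here. No available evidence explains the step.
A 4-chloropentyl group on the same carbon would help separate chain length from the nitrogen. A propylamino group would test the chlorine, which all compounds shown retain.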